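Same atoms, joined differently: from compound 3 to compound 4

This account rests on a few compounds, and the source may have more. Where it says the series, first, only, none or still open, it means among the compounds named here.

Compound 1 `CC(=O)N1CCC(c2cnc(NCc3c(F)ccc4c3CCO4)c3cn[nH]c(=O)c23)CC1`: 2.9
Compound 2 `Cc1cc(-c2cnc(NCc3c(F)ccc4c3CCO4)c3cn[nH]c(=O)c23)n(C)n1`: 3
Compound 3 `CNC(=O)c1cc(-c2cnc(NCc3c(F)ccc4c3CCO4)c3cn[nH]c(=O)c23)n(C)n1`: 2.1

All three numbers come from a physicochemical assay for lipophilicity, using the shake flask method, in phosphate buffer, measured as octanol-water partition, with a stated time of 30 min, at pH 7.4; on this read-out lower numbers stand for lower lipophilicity and higher numbers for higher lipophilicity. Compound 3 has the lowest number of the three, and two measured steps show the gap: a number 0.80 log units lower from compound 1 to compound 3 (beyond the scatter), and a number 0.90 log units lower from compound 2 to compound 3 (beyond the scatter).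

Compound 4 `CNC(=O)c1ncc(-c2cnc(NCc3c(F)ccc4c3CCO4)c3cn[nH]c(=O)c23)n1C` has not been measured. In it, 1-methyl-2-(methylcarbamoyl)-1H-imidazol-5-yl replaces 1-methyl-3-(methylcarbamoyl)-1H-pyrazol-5-yl on an aromatic carbon of the shared core: 1-methyl-2-(methylcarbamoyl)-1H-imidazol-5-yl in place of 1-methyl-3-(methylcarbamoyl)-1H-pyrazol-5-yl on an aromatic carbon. The two groups have the same atoms, joined differently.

Going by the values given here, no measured step is a swap of this kind, so the evidence is indirect. One step, a number 0.10 log units higher from compound 1 to compound 2 (within the scatter), shows that replacing the whole group need not move the number. Among the compounds with values here, the two larger steps both end at compound 3, the only measured compound with a methylcarbamoyl group, and compound 4 keeps that group. Within the data shown here, no measured compound carries the new group, so the direction is uncertain, and a step within the scatter is expected. The expected step is a number 0.10 log units lower from compound 3 to compound 4 (within the scatter). For compound 4 the estimate is 2, with an expected range from 1.6 to 2.5.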

Compound 4, distribution coefficient: 2.5
For compound 4 the middle estimate is 0.50 log units below the measured one, within the range that was stated.
By their numbers in this assay, from the lowest: compound 3; then compound 4; then compounds 1 and 2 (each within the scatter of the next).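

In this assay, going by these compounds alone, the earlier compounds showed that adding methylcarbamoyl can change the number, and the new result shows that rearranging the atoms of the group can change it too: the step is a number 0.40 log units higher from compound 3 to compound 4 (beyond the scatter) even though the groups that leave and enter have the same atoms and the same counts of donors and acceptors. The other two new steps, a number 0.50 log units lower from compound 2 to compound 4 (beyond the scatter) and a number 0.40 log units lower from compound 1 to compound 4 (beyond the scatter), show that the 1-methyl-2-(methylcarbamoyl)-1H-imidazol-5-yl group still gives a lower number than either group without methylcarbamoyl, so among these four compounds both groups carrying methylcarbamoyl sit below the two that lack it. No measurement shown here accounts for the difference between the two arrangements.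

The compounds shown leave open whether the gap between the two ring arrangements depends on methylcarbamoyl, which a comparison of 1,2-dimethyl-1H-imidazol-5-yl with the 1,3-dimethyl-1H-pyrazol-5-yl of compound 2 could test. They also leave open how the number would respond on either ring if methylcarbamoyl gave way to a carboxylic acid, a nitrile or an amide with a longer chain on its nitrogen.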